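The source may hold more compounds than are shown below. What is called first, only, known or untested is meant among the compounds shown, and "the series" means these compounds.

Three compounds sharing one core were tested in a functional assay on LNCaP cells (Homo sapiens) for cytotoxicity; on this read-out higher numbers stand for an effect only at larger amounts of compound and lower numbers for an effect already at smaller amounts. Compound 1, `CCC[C@@H](OC(C)=O)C1=C(Br)/C(=C/Br)OC1=O`, gives 0.5 ug/mL. Compound 2, `CCC[C@@H](OC(C)=O)C1=C(Br)C(=C(Br)Br)OC1=O`, gives 2.1 ug/mL. Compound 3, `CCC[C@@H](OC(C)=O)C1=C(Br)[C@@](C)(OC)OC1=O`, gives 1.7 ug/mL, the second highest of the three numbers; its gap to compound 2 lies within the scatter, while compound 1 sits clearly lower, beyond the scatter. Compound 4, `CCC[C@@H](OC(C)=O)C1=C(Br)[C@@](CI)(OC)OC1=O`, differs from compound 3 in one place: iodo in place of hydrogen on a saturated chain carbon bound to a saturated ring carbon. Among the compounds with values here, no measured pair shows this kind of change, so its effect cannot be read from the data at hand. The step is expected to be small, within the scatter, no change at the digits printed from compound 3 to compound 4 (within the scatter). Compound 4 is therefore estimated at 1.7 ug/mL, with a range from 0.7 ug/mL to 4 ug/mL.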

Compound 4, concentration for half-maximal effect: 12.9 ug/mL
Compound 4: middle estimate off by 7.6-fold (0.88 log units), on the low side; measured number above the stated range.
By their numbers in this assay, from the lowest: compound 1; then compounds 3 and 2 (each within the scatter of the next); then compound 4.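

Iodo in place of hydrogen on a saturated chain carbon bound to a saturated ring carbon is not a silent change in this assay: it gives a 7.6-fold higher number from compound 3 to compound 4 (0.88 log units; beyond the scatter). The earlier compounds shown here carried nothing but the plain methyl at this place, and this step shows that the number responds to what is attached there. No evidence at hand bears on the reason for this step.

As far as these compounds go, it remains open whether this holds only for iodomethyl, or whether chloromethyl, hydroxymethyl or aminomethyl at the same place would move the number in the same way.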